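This account rests on a few compounds, and the source may have more. Where it says the series, first, only, none or still open, it means among the compounds named here.

Compound 1 `CCCC/C=C\CCCCCCCCCc1cc(=O)c2c(O)cc(OCOC)c(C)c2o1`: > 67200 nM
Compound 2 `CCCCC/C=C\C/C=C\CCCCCCCc1cc(=O)c2c(O)c(C)c(OCOC)c(C)c2o1`: > 84100 nM
Compound 3 `CCCCC/C=C\C/C=C\CCCCCCCc1cc(=O)c2c(O)cc(OCOC)cc2o1`: > 67200 nM

The three measured compounds share one core and were tested in a functional assay on MCF7 cells (Homo sapiens) for antiproliferative activity, read by MTT assay; on this read-out lower numbers stand for stronger inhibition and higher numbers for weaker inhibition. None of them gave a number. Compound 1 reached only a limit of this assay, > 67200 nM. Compound 2 also stopped at a limit, > 84100 nM. Compound 3 stands at a limit as well, > 67200 nM, so its place among the three cannot be ranked: two values sit at the limit of > 67200 nM in this assay, at which 2 of the 3 values shown sit, and one at the limit of > 84100 nM in this assay, at which 1 of the 3 values shown sits, and all three are limits rather than measurements.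

Compound 4 `CCCCC/C=C\C/C=C\CCCCCCCc1cc(=O)c2c(O)cc(OCOC)c(C)c2o1` differs from compound 3 in a single spot: methyl in place of hydrogen on an aromatic carbon. Among the measured compounds shown here, no step between two measured compounds with numbers is available, so the size of this change in this assay cannot be read from the data. Given that compound 3 gave only a limit, > 67200 nM, compound 4 is expected to show no step beyond the scatter, a step that the limit leaves unreadable from compound 3 to compound 4. Compound 4 is therefore estimated at 70000 nM, within a range of 30000 nM to 200000 nM, and most likely as a limit again.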

Compound 4, half-maximal inhibitory concentration: > 84100 nM
Compound 4 gave a limit, no number (the forecaster's own chance of this, stated with the estimate: 80%); middle value at least 1.2-fold (0.07 log units) from the limit.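

In this assay compound 4 gave only a limit, > 84100 nM. Among the compounds shown here, with compound 1, compound 2 and compound 3 also at limits, no step to compound 4 can be read. The compounds shown leave open whether swapping methyl for hydrogen on the aromatic carbon, or changing the chain, shifts the read-out in this assay at all.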